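The compounds below may be only part of what the source reports. "The series", "measured", "known", "first", "only" and "open" are said of these compounds alone.

In a functional assay on SGC-7901 cells (Homo sapiens) for inhibition, read by MTT assay, with a stated time of 72 h (a higher number here means a weaker inhibitor, a lower number a stronger inhibitor), compound 1 `O=C(NCc1ccc(NC(=O)c2cc(F)ccc2N2CCCC2)cc1)OCc1cccnc1` gives 44800 nM. Compound 2 `O=C(NCc1ccc(NC(=O)c2cc(C(F)(F)F)ccc2N2CCCC2)cc1)OCc1cccnc1` gives only a limit, > 100000 nM, so it has no exact number. Going by the values given here, the one measured step that bears on what follows, an at least 2.2-fold higher number from compound 1 to compound 2 (0.34 log units; beyond the scatter), came with trifluoromethyl in place of fluoro on an aromatic carbon. Compound 3 `O=C(NCc1ccc(NC(=O)c2cc(Br)ccc2N2CCCC2)cc1)OCc1cccnc1` has bromo in place of trifluoromethyl on that same carbon (bromo in place of trifluoromethyl on an aromatic carbon). Going by that single step, a move back to a lower number, toward compound 1, is expected. The expected size is an at least 1.6-fold lower number from compound 2 to compound 3 (0.22 log units; that floor lies within the scatter), an uncertain figure with no exact number to start from. For compound 3 the estimated value is 60000 nM, with an expected range of 25000 nM to 100000 nM.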

Compound 3, half-maximal inhibitory concentration: > 100000 nM
Compound 3: no number, only a limit (the forecaster's own chance of this, stated with the estimate: 30%); middle value at least 1.6-fold (0.22 log units) away from the limit.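

In this assay, bromo in place of fluoro on this carbon, para to a pyrrolidin-1-yl group, gives an at least 2.2-fold higher number from compound 1 to compound 3 (0.34 log units; beyond the scatter). Among these three compounds, only the fluoro group gives an exact number, while trifluoromethyl and bromo both end in a limit of the assay. The step from compound 2 to compound 3 cannot be read, because both values are limits: the limit of > 100000 nM in this assay, at which 2 of the 3 values shown sit.

As far as these compounds go, the true values of compound 2 and compound 3 stay open. Also open, from the compounds shown here alone, is whether chloro, methoxy or an amine on this carbon would give an exact number.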